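The source may hold more compounds than are shown below. What is called first, only, known or untested is meant among the compounds shown, and "the series" means these compounds.

The series shares one core, an ester of a methyl-piperidinol, and differs only in the aromatic acid part. Compound 1 is `CN1CCC(OC(=O)c2ccccc2Cc2ccccc2)CC1`, compound 2 is `CN1CCC(OC(=O)c2ccc(Cl)c(Cl)c2)CC1` and compound 3 is `COc1cc(OC)cc(C(=O)OC2CCN(C)CC2)c1`. All three have been tested in a functional assay on the whole organism with Mus musculus as the target; a higher number here means a more potent compound, by a factor of ten per unit of this negative logarithm, a lower number a less potent compound. Compound 1 gives 1.28 in this assay. Compound 2 gives 1.08, and compound 3 gives 1.53. The three numbers all lie within the usual scatter of one another, so none of the compounds can be called more or less potent than the others on this evidence; compound 1 sits among them without standing apart.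

Compound 4, `COc1ccccc1C(=O)OC1CCN(C)CC1`, has not yet been measured in this assay. It differs from compound 1 in one place: methoxy in place of benzyl on an aromatic carbon. Going by the values given here, no pair of measured compounds isolates this change, so its effect has to be guessed. Compound 3, whose acid part carries two methoxy groups, gives 1.53, which is within the scatter of compound 1; that is the only hint available. The step from compound 1 to compound 4 is therefore expected to be small, a number 0.12 log units higher from compound 1 to compound 4 (within the scatter), and not beyond the scatter in either direction. Compound 4 is estimated to give 1.4 in this assay, within a range of 0.9 to 1.9.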

Compound 4, logarithm of the reciprocal of the active concentration, log(1/C): 1.43
Beside the measured number, compound 4's estimate is 0.03 log units below it, within the range that was stated.
By their numbers in this assay, from the lowest: compounds 2, 1, 4 and 3 (each within the scatter of the next, the first and the last beyond it).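

In this assay, going by these compounds alone, methoxy in place of benzyl on an aromatic carbon, ortho to a large group, gives a number 0.15 log units higher from compound 1 to compound 4 (within the scatter) and is the first step that isolates a single place. At this position, therefore, the benzyl group with its six-membered aromatic ring and the methoxy group, which has no ring and brings a hydrogen-bond acceptor, cannot be told apart on this read-out. The aromatic ring of the benzyl group is thus not shown to matter here, and the added acceptor is not shown to matter either, though a step within the scatter cannot exclude a small effect of either kind, and nothing measured alongside these compounds speaks to the reason for the result.

The compounds shown leave open whether a step beyond the scatter can be reached at this position at all, for instance with an amine, a carboxylic acid or a longer chain such as butoxy. They also leave open whether methoxy in place of benzyl would read the same way on a different carbon of the aromatic ring.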